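This account rests on a few compounds, and the source may have more. Where it says the series, first, only, none or still open, it means among the compounds named here.

Compound 1 `O=C1C(Nc2ccc(Br)cc2)=CC(=O)c2c1nc1n2[C@H]2OC[C@@H](O)[C@H]2OC1` and compound 2 `Cc1ccc(NC2=CC(=O)c3c(nc4n3[C@H]3OC[C@@H](O)[C@H]3OC4)C2=O)cc1` carry an aryl group on the amine nitrogen of a shared core. In a functional assay on HeLa cells (Homo sapiens) for inhibition, read by sulforhodamine B assay (on this read-out lower numbers stand for stronger inhibition and higher numbers for weaker inhibition), compound 1 gives 5220 nM and compound 2 gives 6590 nM, so that swapping bromo for methyl brings a 1.3-fold higher number from compound 1 to compound 2 (0.10 log units; within the scatter). Compound 3 `O=C1C=C(NC2CCCCC2)C(=O)c2c1nc1n2[C@H]2OC[C@@H](O)[C@H]2OC1` carries cyclohexyl there, and in this assay compound 3 gives only a limit, > 16000 nM, which is the limit of > 16000 nM in this assay, at which 1 of the 3 values shown sits. Compound 4 `CCOc1ccccc1NC1=CC(=O)c2nc3n(c2C1=O)[C@H]1OC[C@@H](O)[C@H]1OC3` is not yet measured and differs from compound 3 by 2-ethoxyphenyl in place of cyclohexyl on an amine nitrogen. Among the measured compounds shown here, no measured step covers this swap, but both aryl compounds 1 and 2 sit at numbers while the cyclohexyl compound 3 sits at a limit, so a move to stronger inhibition, expected as an at least 2.4-fold lower number from compound 3 to compound 4 (0.39 log units; beyond the scatter), seems likely. Compound 4 is therefore estimated at 6500 nM, between 3000 nM and 16000 nM.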

Compound 4, half-maximal inhibitory concentration: 6040 nM
Compound 4: the middle estimate sits 1.1-fold (0.03 log units) above what was measured; the measured number falls inside the stated range.
By their numbers in this assay, from the lowest: compounds 1, 4 and 2 (each within the scatter of the next). At a limit, above all of these: compound 3.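

In this assay, among the compounds shown here, this is the first change at the amine nitrogen that lies beyond the scatter (an at least 2.6-fold lower number from compound 3 to compound 4 (0.42 log units; beyond the scatter)), whereas the swap of bromo for methyl on the aryl group stayed within it. From the compounds shown here alone, the true size of this step remains unknown, since compound 3 stands only at a limit: the limit of > 16000 nM in this assay, at which 1 of the 4 values shown sits.

The step replaces a non-aromatic ring with an aromatic one and adds the ethoxy group at once, so the two changes cannot be separated. Plain phenyl, an amine on the ring, or a longer chain on the nitrogen remain open.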